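The source may hold more compounds than are shown below. What is called first, only, known or untested is meant among the compounds shown, and "the series" means these compounds.

Working notes on the series. The shared core carries a phenylthiazole unit with a pyrimidinylsulfanyl acetohydrazide arm; compound 1 `O=C(CSc1ncccn1)N/N=c1/scc(-c2ccccc2)n1-c1ccccc1` is the unsubstituted parent, and in a functional assay on C6 cells (Rattus norvegicus) for cytotoxicity, read by MTT assay, with a stated time of 24 h (on this read-out lower numbers stand for stronger inhibition and higher numbers for weaker inhibition), compound 1 is recorded as "not determined" (no result reported). For the measured compounds named here, compound 2 `O=C(CSc1ncccn1)N/N=c1/scc(-c2ccc(Cl)cc2)n1-c1ccccc1` carries a chloro on the pendant phenyl ring, and in this assay compound 2 gives 83.3 ug/mL; this is the only number available, so compound 2 stands alone and no step between measured compounds can be drawn.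

Compound 3 `Cc1ccc(-c2cs/c(=N/NC(=O)CSc3ncccn3)n2-c2ccccc2)cc1` is the next entry. It differs from compound 2 only in that (methyl in place of chloro on an aromatic carbon). Going by the values given here, with no comparable step on record, the expectation for compound 3 rests on the single value of compound 2 alone, so the step of a 1.1-fold higher number from compound 2 to compound 3 (0.06 log units; within the scatter) is estimated to stay close to the scatter, with a lean toward a higher number. On that basis compound 3 is expected to give about 95 ug/mL in this assay, estimated within a range of 45 ug/mL to 200 ug/mL.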

Compound 3, half-maximal inhibitory concentration: 85 ug/mL
Compound 3: the middle estimate sits 1.1-fold (0.05 log units) above what was measured, and the stated range covers the measured number.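

In this assay, for the compounds shown here, the change from 4-chlorophenyl to 4-methylphenyl gives a 1.0-fold higher number from compound 2 to compound 3 (0.01 log units; within the scatter), the first step that can be read. At this place, on an aromatic carbon para to a large group, chloro and methyl cannot be told apart on this read-out, so the exchange of one of these single heavy atoms for the other leaves the cytotoxicity reading unchanged within the scatter. No supporting measurement is available to explain this result.

On these data alone, whether the position responds to other groups remains open: an amine, a carboxylic acid or a longer alkyl chain might read differently. Compound 1, the unsubstituted parent, stands at "not determined" (no result reported), so a step from hydrogen to either chloro or methyl cannot be read.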